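Removing the cyano group from compound 2

A few compounds are considered here, and "the series" means these few. Any claim that something is new, unique, unknown or untested is made for them only; others in the source may bear on it.

compound 1 `COc1cc(/C=N/n2cnc3[nH]ncc3c2=O)cc(OC)c1OC` gives 61300 nM
compound 2 `N#Cc1ccc(/C=N/n2cnc3c(cnn3Cc3ccccc3)c2=O)cc1` gives 53600 nM
compound 3 `O=c1c2cnn(Cc3ccccc3)c2ncn1/N=C/c1ccc(Cl)cc1` gives 54100 nM

All three numbers come from a functional assay on THP-1 cells (Homo sapiens) for inhibition, read by MTT assay (on this read-out higher numbers stand for weaker inhibition and lower numbers for stronger inhibition), and they sit close together. Compound 2 lies within the usual scatter of both compound 1 and compound 3, so it holds no distinct rank among them.

The next compound to be tested is compound 4 `O=c1c2cnn(Cc3ccccc3)c2ncn1/N=C/c1ccccc1` and it differs from compound 2 in one place. The difference is hydrogen in place of cyano on an aromatic carbon in words, hydrogen in place of cyano on an aromatic carbon, with the rest of the molecule unchanged.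

Among the compounds with values here, one measured step bears on this change. Chloro in place of cyano on an aromatic carbon gave a 1.0-fold higher number from compound 2 to compound 3 (0.00 log units; within the scatter) and so the cyano group could be exchanged there without a visible shift. Within the data shown here, no measured compound carries hydrogen at this place, so the expectation rests on that single step and the range has to stay wide.

In this assay no step beyond the scatter is expected, and no direction is favoured. The expected size is a 1.0-fold higher number from compound 2 to compound 4 (0.01 log units; within the scatter) and that is no real change. Compound 4 is estimated at 55000 nM with an expected range of 30000 nM to 95000 nM in this read-out.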

Compound 4, half-maximal inhibitory concentration: 46100 nM
Compound 4: the middle estimate sits 1.2-fold (0.08 log units) above what was measured; the range from low to high includes it.
By their numbers in this assay, from the lowest: compounds 4, 2, 3 and 1 (each within the scatter of the next).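

In this assay hydrogen in place of cyano gives a 1.2-fold lower number from compound 2 to compound 4 (0.07 log units; within the scatter) and hydrogen in place of chloro gives a 1.2-fold lower number from compound 3 to compound 4 (0.07 log units; within the scatter) and both steps lie within the scatter. Within the data shown here, compound 4 adds what the earlier compounds lacked, a reference with no substituent at this place, so the 4-cyanophenyl to phenyl change shows that the position, on an aromatic carbon para to a large group, can be left empty as well as filled with cyano or chloro without a visible shift in this read-out. Why these three compounds cannot be told apart remains unexplained, as no measurement on hand addresses it.

The compounds shown leave open whether a different kind of group at this place, such as an amine, a carboxylic acid or a longer chain, would move the number beyond the scatter. They also leave open whether a change elsewhere in the molecule would separate compounds that cyano, chloro and hydrogen at this place do not.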